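Ferulate esters on SKBR cells: nitrooxy chain to isopropyl

The compounds below may be only part of what the source reports. "The series", "measured", "known", "first", "only" and "open" are said of these compounds alone.

Among the compounds with values here, compound 2 `COc1cc(/C=C/C(=O)OCCCO[N+](=O)[O-])ccc1O` gives 17200 nM in a functional assay on SKBR cells (Homo sapiens) for cytotoxicity, read by resazurin assay, with a stated time of 72 h (a lower number here means a stronger inhibitor, a higher number a weaker inhibitor), the higher of the two numbers known so far, while compound 1 `COc1cc(/C=C/C(=O)OC/C=C/CO[N+](=O)[O-])ccc1O` gives 6530 nM in this assay. Within the data shown here, the one measured step, a 2.6-fold higher number from compound 1 to compound 2 (0.42 log units; beyond the scatter), shows that shortening the nitrooxy-bearing chain already weakened the compound. Compound 3 `COc1cc(/C=C/C(=O)OC(C)C)ccc1O` goes further: isopropyl in place of 3-(nitrooxy)propyl on an oxygen next to a carbonyl group. Among the measured compounds shown here, with no step that removes the nitrate group to compare against, only the direction of the change from compound 1 to compound 2 can guide the expectation. Compound 3 is therefore expected to be weaker still, with a step of about a 2.3-fold higher number from compound 2 to compound 3 (0.37 log units; beyond the scatter), estimated at 40000 nM with a range of 15000 nM to 120000 nM.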

Compound 3, half-maximal inhibitory concentration: > 50000 nM
Compound 3: a limit, no number (the forecaster's own chance of this, stated with the estimate: 25%); middle value at least 1.2-fold (0.09 log units) from the limit.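

Replacing the chain with a group that has no nitrogen or extra oxygen gives an at least 2.9-fold higher number from compound 2 to compound 3 (0.46 log units; beyond the scatter), so this ester oxygen has now been seen to carry a group lacking the nitrooxy function, and the compound does not gain activity. Compound 3 gives a limit, not a number, so the true size of this step stays unknown: the limit of > 50000 nM in this assay, at which 1 of the 3 values shown sits.

The compounds shown leave open how much of this loss belongs to the nitrooxy group and how much to the chain itself. A 3-hydroxypropyl ester would separate the two, and a longer chain carrying the nitrooxy group would test the other direction.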